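The source may report more compounds than this note shows. Statements on the series, on what has been measured and on what is new or still open speak of the compounds shown alone.

Compound 2, `Nc1nc(O)c2c(n1)n(C1OC(CO)[C@@H](O)[C@H]1O)c(=O)n2Cc1ccc(OCc2ccccc2)cc1`, is the starting point of this account. In a functional assay (B cells) with Mus musculus as the target (on this read-out lower numbers stand for an effect already at smaller amounts and higher numbers for an effect only at larger amounts of compound), compound 2 gives 8 uM, the lowest of the two numbers measured here. The nearest comparison is compound 1, `[N-]=[N+]=NCC(O)Cn1c(=O)n(C2OC(CO)[C@@H](O)[C@H]2O)c2nc(N)nc(O)c21`, which in this assay gives 39 uM, a higher number that lies beyond the usual scatter of repeated measurements. Within the data shown here, no pair of measured compounds differs in a single place, so no measured step is available to guide the next change. Compound 3, `Nc1nc(O)c2c(n1)n(C1OC(CO)[C@@H](O)[C@H]1O)c(=O)n2Cc1ccc([N+](=O)[O-])cc1`, differs from compound 2 as follows: nitro in place of benzyloxy on an aromatic carbon. Among the measured compounds shown here, nothing among the measured compounds shows what this replacement does, so the expectation rests on the value of compound 2 alone. The step from compound 2 to compound 3 is expected to be modest, a 1.9-fold higher number from compound 2 to compound 3 (0.27 log units; within the scatter), toward a somewhat higher number but hardly beyond the scatter. Compound 3 is therefore estimated at 15 uM, with a range from 5 uM to 45 uM.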

Compound 3, concentration for half-maximal effect: 40 uM
Compound 3: the middle estimate sits 2.7-fold (0.43 log units) below what was measured; low and high end bracket the measured number.
By their numbers in this assay, from the lowest: compound 2; then compounds 1 and 3 (each within the scatter of the next).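

In this assay, among these compounds, the change of benzyloxy to nitro on an aromatic carbon gives the first single-place step at this position, a 5.0-fold higher number from compound 2 to compound 3 (0.70 log units; beyond the scatter), and so shows that the number responds to the group placed there. Benzyloxy is therefore not interchangeable with nitro on this read-out, although the step alone cannot separate the loss of benzyloxy from the entry of nitro. The second step, with 4-nitrophenyl in place of 2-azido-1-hydroxyethyl on a saturated chain carbon bound to an aromatic nitrogen, is a 1.0-fold higher number from compound 1 to compound 3 (0.01 log units; within the scatter), so these two groups are not told apart in this assay.

No other data bear on why the number changes with benzyloxy and nitro. As far as these compounds go, how a methoxy group, an amine or a carboxylic acid on that same aromatic carbon would read remains open.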